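Chloro steps and a 3-nitrophenyl replacement

A few compounds are considered here, and "the series" means these few. Any claim that something is new, unique, unknown or untested is made for them only; others in the source may bear on it.

In a functional assay on THP-1 cells (Homo sapiens) for cytotoxicity, read by MTT assay, with a stated time of 24 h (on this read-out lower numbers stand for stronger inhibition and higher numbers for weaker inhibition), compound 1 (`COc1cc(/C=C2\CN(C)C/C(=C\c3ccc(Cl)cc3)C2=O)cc(OC)c1OC`) gives 7200 nM and compound 2 (`COc1cc(/C=C2\CN(C)C/C(=C\c3ccc(Cl)cc3Cl)C2=O)cc(OC)c1OC`) gives 5020 nM while compound 3 (`COc1cc(/C=C2\CN(C)C/C(=C\c3ccc(Cl)c(Cl)c3)C2=O)cc(OC)c1OC`) gives 5330 nM on the same read-out. Compound 3 sits within the scatter of the other two, the gaps being a 1.1-fold higher number from compound 2 to compound 3 (0.03 log units; within the scatter) and a 1.4-fold lower number from compound 1 to compound 3 (0.13 log units; within the scatter) on this read-out. Compound 4 (`COc1cc(/C=C2\CN(C)C/C(=C\c3cccc([N+](=O)[O-])c3)C2=O)cc(OC)c1OC`) brings one change 3-nitrophenyl in place of 3,4-dichlorophenyl on a double-bonded chain carbon bound to a double-bonded ring carbon that puts 3-nitrophenyl in place of 3,4-dichlorophenyl on a double-bonded chain carbon bound to a double-bonded ring carbon. Going by the values given here, only chloro steps bear on this: a 1.4-fold lower number from compound 1 to compound 2 (0.16 log units; within the scatter) and a 1.4-fold lower number from compound 1 to compound 3 (0.13 log units; within the scatter) stayed within the scatter, and no measured compound carries a nitro group. The expected step is a 1.1-fold lower number from compound 3 to compound 4 (0.03 log units; within the scatter) in this assay and nothing beyond the scatter is expected. For compound 4 the estimated value is 5000 nM with an expected range from 2300 nM to 11000 nM on this read-out.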

Compound 4, half-maximal inhibitory concentration: 890 nM
Beside the measured number, compound 4's estimate is 5.6-fold (0.75 log units) above it; measured number below the stated range.
By their numbers in this assay, from the lowest: compound 4; then compounds 2, 3 and 1 (each within the scatter of the next).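

At this position the aryl group does move the number in this assay: the 3-nitrophenyl replacement gives a 6.0-fold lower number from compound 3 to compound 4 (0.78 log units; beyond the scatter) and a 5.6-fold lower number from compound 2 to compound 4 (0.75 log units; beyond the scatter) and an 8.1-fold lower number from compound 1 to compound 4 (0.91 log units; beyond the scatter) while the chloro steps all stayed within the scatter. The chlorophenyl compounds alone therefore gave no sign of how much this position can change the read-out. Nothing measured here explains the step.

Still open, going by these compounds, is whether the step belongs to the nitro group itself or to the loss of chlorine. An amine or a nitrile on the same phenyl ring would help separate the two.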